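Thiazole Carboxamides: Swapping an Aryl Ether for an Arylamine

This account rests on a few compounds, and the source may have more. Where it says the series, first, only, none or still open, it means among the compounds named here.

Measured so far:
Compound 1, `O=C(Nc1ccc(C(F)(F)C(F)(F)F)cc1)c1csc(Cc2c(Cl)cccc2Cl)n1`, gives 350 nM in an assay on CHO cells, read by calcium flux; a higher number here means a weaker inhibitor, a lower number a stronger inhibitor.
Compound 2, `O=C(Nc1ccc(C(F)(F)F)cc1)c1csc(Oc2c(Cl)cccc2Cl)n1`, gives 1280 nM in this assay.

Among these two numbers compound 2 stands highest, and the nearest value, that of compound 1, is well beyond the usual scatter of repeated measurements. The two compounds differ in more than one place, so the gap says only what the two values show, and no single cause can be read from it.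

The next compound, compound 3, `Cc1cccc(C)c1Nc1nc(C(=O)Nc2ccc(C(F)(F)F)cc2)cs1`, is not yet measured. It differs from compound 2 in one place: (2,6-dimethylphenyl)amino in place of 2,6-dichlorophenoxy on an aromatic carbon. The group that leaves and the one that enters are of the same size, and the newcomer brings a hydrogen-bond donor where none was before.

Among the measured compounds shown here, no measured pair shows what such a swap does in this assay, so the expectation rests on compound 2 alone. A modest step is expected, most likely not clearly beyond the scatter, with a slight lean toward a lower number, which is what a 1.4-fold lower number from compound 2 to compound 3 (0.15 log units; within the scatter) expresses. Compound 3 is therefore estimated at 900 nM, in a range from 300 nM to 2700 nM.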

Compound 3, half-maximal inhibitory concentration: 82 nM
The estimate for compound 3 lay 11-fold (1.04 log units) above the measured number; measured number outside the range, below it.
By their numbers in this assay, from the lowest: compound 3; then compound 1; then compound 2.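

In this assay the swap at this aromatic carbon of the five-membered ring gives a 16-fold lower number from compound 2 to compound 3 (1.19 log units; beyond the scatter), so the number responds strongly to what sits at this position, even though the leaving and entering groups have the same count of heavy atoms. Two things change within this one swap: the oxygen linking the six-membered aromatic ring to the core gives way to a nitrogen carrying a hydrogen, which adds a hydrogen-bond donor, and the two chlorine atoms give way to two methyl groups. Nothing measured here accounts for the size of this step, so it stands as an observation only.

The compounds shown leave open which of these two changes carries the step, and a (2,6-dichlorophenyl)amino group or a 2,6-dimethylphenoxy group at this position on the core of compound 3 would pull them apart. As far as these compounds go, whether the hydrogen on the linking nitrogen matters also stays open, and a linking nitrogen bearing a methyl group in place of that hydrogen would speak to it.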